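Bromo in place of chloro on compound 3

The source may hold more compounds than are shown below. What is called first, only, known or untested is meant among the compounds shown, and "the series" means these compounds.

In an ADME assay on HEK-293T cells (Homo sapiens) for cytotoxicity, read by MTT assay, with a stated time of 24 h (a lower number here means that less compound is tolerated, a higher number that more compound is tolerated), compound 3 (`O=S(=O)(c1ccc(Cl)cc1)n1c(-c2cn(-c3ccccc3)nc2-c2ccc(F)cc2)nc2ccccc21`) gives 93100 nM and lies within the scatter of the other two compounds: compound 1 (`Cc1ccc(-c2nn(-c3ccccc3)cc2-c2nc3ccccc3n2S(=O)(=O)c2ccc(Br)cc2)cc1`) gives 159000 nM and compound 2 (`Cc1ccc(C)c(S(=O)(=O)n2c(-c3cn(-c4ccccc4)nc3-c3ccc(F)cc3)nc3ccccc32)c1`) gives 54200 nM in this test. Compound 4 (`O=S(=O)(c1ccc(Br)cc1)n1c(-c2cn(-c3ccccc3)nc2-c2ccc(F)cc2)nc2ccccc21`) differs from compound 3 by one change: bromo in place of chloro on an aromatic carbon with bromo in place of chloro on an aromatic carbon, para to a large group. Among the measured compounds shown here, the one measured step at the sulfonyl group, a 1.7-fold higher number from compound 2 to compound 3 (0.23 log units; within the scatter) for 4-chlorophenyl in place of 2,5-dimethylphenyl, stayed within the scatter. Compound 1 carries the 4-bromophenyl group too but differs from compound 4 elsewhere, so it offers no direct comparison. The estimate is a 1.1-fold higher number from compound 3 to compound 4 (0.05 log units; within the scatter) in this assay and so no change beyond the scatter is expected. For compound 4 the expected value is 105000 nM with 60000 nM to 185000 nM as the estimated range.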

Compound 4, half-maximal cytotoxic concentration: 239000 nM
Estimate against measurement, compound 4: 2.3-fold (0.36 log units) below; measured number outside the range, above it.
By their numbers in this assay, from the lowest: compounds 2, 3, 1 and 4 (each within the scatter of the next, the first and the last beyond it).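

In this assay, among the compounds shown here, this position gives the first step beyond the scatter: bromo in place of chloro on an aromatic carbon gives a 2.6-fold higher number from compound 3 to compound 4 (0.41 log units; beyond the scatter), so one halogen swap alone can move the number. The 4-bromophenyl group in place of 2,5-dimethylphenyl gives a 4.4-fold higher number from compound 2 to compound 4 (0.64 log units; beyond the scatter), while fluoro in place of methyl on an aromatic carbon gives only a 1.5-fold higher number from compound 1 to compound 4 (0.18 log units; within the scatter). No measurement shown here accounts for the bromo result. Going by these compounds, whether iodo or an amine at this position would go further stays open, as does whether the step from chloro to bromo holds on the core of compound 1.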